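Microsomal clearance: 1,3-oxazol-2-yl in place of pyridin-3-yl

The source may hold more compounds than are shown below. What is called first, only, known or untested is meant among the compounds shown, and "the series" means these compounds.

Measured compounds:
compound 1 `CC(C)n1nc(Cn2nc3ccccc3c2CCCO)c2ccccc21`: 78 mL.min-1.g-1
compound 2 `O=c1n(Cc2nc(-c3cccnc3)cn2CCCCO)c2cnccc2n1C1CC1`: < 8 mL.min-1.g-1

In an ADME assay on microsomes from liver (Homo sapiens) for metabolic stability (a higher number here means faster removal of the compound, a lower number slower removal), compound 1 gives 78 mL.min-1.g-1. For compound 2 the result is only a limit, < 8 mL.min-1.g-1, which is the limit of < 8 mL.min-1.g-1 in this assay, at which 1 of the 2 values shown sits. Compound 2 thus sits at the lower end of the two values shown, and no number is known for it beyond that limit.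

Compound 3 `O=c1n(Cc2nc(-c3ncco3)cn2CCCCO)c2cnccc2n1C1CC1` differs from compound 2 by 1,3-oxazol-2-yl in place of pyridin-3-yl on an aromatic carbon. Among the measured compounds shown here, no pair of measured compounds differs in one place, so no measured step size is available for comparison.

The change is expected to move this assay by no more than the scatter, in either direction. Compound 3 is estimated at 8 mL.min-1.g-1, with a range from 4 mL.min-1.g-1 to 20 mL.min-1.g-1. The estimated step of a number no lower from compound 2 to compound 3 (the limit leaves the size open) is expected to stay within the scatter, with a fair chance that compound 3 again returns only the limit.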

Compound 3, intrinsic clearance in microsomes: < 8 mL.min-1.g-1
Compound 3: no number, only a limit; the forecaster's own chance of this, stated with the estimate: 50%; the middle value lies on the limit itself.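

In this assay compound 2 and compound 3 each return only a limit, so no step between them can be read: the limit of < 8 mL.min-1.g-1 in this assay, at which 2 of the 3 values shown sit.

On these data alone, whether 1,3-oxazol-2-yl in place of pyridin-3-yl on an aromatic carbon shifts this assay at all remains open.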